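Carbonyl substituent change from compound 1 to compound 3

The source may hold more compounds than are shown below. What is called first, only, known or untested is meant among the compounds shown, and "the series" means these compounds.

Measured so far:
compound 1 `O=C(c1cccc(Nc2ncc(F)c(Nc3ccc(F)cc3)n2)c1)N1CCCCC1`: 14800 nM
compound 2 `COc1ccc(N2CCN(C)CC2)cc1Nc1ncc(F)c(Nc2ccc(F)cc2)n1`: 960 nM

In a functional assay on KB cells (Homo sapiens) for antiproliferative activity, read by sulforhodamine B assay, with a stated time of 3 days (a lower number here means a stronger inhibitor of growth, a higher number a weaker inhibitor of growth), compound 1 stands at the highest of the two numbers; compound 2 sits lower, the gap beyond the scatter. Compound 3 `COc1cc(NC(=O)c2cccc(Nc3ncc(F)c(Nc4ccc(F)cc4)n3)c2)cc(OC)c1` is not yet measured and differs from compound 1 by (3,5-dimethoxyphenyl)amino in place of piperidin-1-yl on a carbonyl carbon. Among the measured compounds shown here, no step between measured compounds covers this change, so the expectation rests on the change alone. A modest move toward a lower number is expected, a 2.1-fold lower number from compound 1 to compound 3 (0.33 log units; beyond the scatter), though it may not exceed the scatter. Compound 3 is accordingly estimated at 7000 nM, within 2000 nM to 30000 nM.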

Compound 3, concentration for 50% growth inhibition: 15500 nM
Estimate against measurement, compound 3: 2.2-fold (0.35 log units) below; low and high end bracket the measured number.
By their numbers in this assay, from the lowest: compound 2; then compounds 1 and 3 (each within the scatter of the next).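

On the carbonyl carbon whose other neighbour is an aromatic carbon, (3,5-dimethoxyphenyl)amino in place of piperidin-1-yl gives a 1.0-fold higher number from compound 1 to compound 3 (0.02 log units; within the scatter) in this assay. This position therefore accepts an aromatic ring with two methoxy groups and an amide hydrogen without a shift beyond the scatter, so this swap does not separate the two compounds. No measured property is available to account for this result.

As far as these compounds go, whether a simple alkylamine, a carboxylic acid or a longer chain on this carbonyl carbon would shift the number stays open. Among the compounds shown here, compound 2 differs from compound 1 in more than one place, so no step links it to this position.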